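A few compounds are considered here, and "the series" means these few. Any claim that something is new, unique, unknown or untested is made for them only; others in the source may bear on it.

Two compounds of this study carry the same core and have been measured. Compound 1 `C/C(=N\Nc1nc2ccccc2o1)c1cc2ccccc2cn1` gives 100 nM in a functional assay on HeLa cells (Homo sapiens) for antiproliferative activity, read by sulforhodamine B assay; a lower number here means a stronger inhibitor, a higher number a weaker inhibitor. Compound 2 `CC(C)/C(=N\Nc1nc2ccccc2o1)c1ccccn1` gives 185 nM in this assay. Compound 2 thus holds the larger of the two numbers, but the gap to compound 1 is within the usual scatter of repeated measurements, so the two cannot be told apart on these data alone.

Compound 3 `CCC/C(=N\Nc1nc2ccccc2o1)c1ccccn1` has not yet been measured. It differs from compound 2 in a single spot: propyl in place of isopropyl on a carbon with a double bond to nitrogen. The two compounds contain the same atoms, joined differently, and the group that enters carries the same count of carbons as the one that leaves.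

Going by the values given here, no pair of measured compounds shows the effect of such a change, so nothing in the data points in either direction. The expected step from compound 2 to compound 3 in this assay is therefore small, a 1.1-fold higher number from compound 2 to compound 3 (0.03 log units; within the scatter), and not beyond the scatter. Compound 3 is expected to give about 200 nM, within a range from 90 nM to 450 nM.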

Compound 3, half-maximal inhibitory concentration: 153 nM
Beside the measured number, compound 3's estimate is 1.3-fold (0.12 log units) above it; low and high end bracket the measured number.
By their numbers in this assay, from the lowest: compounds 1, 3 and 2 (each within the scatter of the next).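

Going by these compounds alone, putting propyl in place of isopropyl on a carbon with a double bond to nitrogen gives a 1.2-fold lower number from compound 2 to compound 3 (0.08 log units; within the scatter) in this assay, and this is the first pair that isolates a single change. At this position, the straight chain and the branched chain, which carry the same count of carbons, cannot be told apart in this assay, so rearranging these carbons has no readable effect on the antiproliferative result. No separate measurement on these compounds is available to help interpret this outcome.

Going by these compounds, the two chains alone cannot show how much this carbon tolerates, so it remains open whether a longer chain such as butyl, a small ring such as cyclopropyl, or a chain ending in an amine would shift the number beyond the scatter. Also open, on these data alone, is whether propyl and isopropyl would again match on the core of compound 1, since compound 1 differs from compound 2 and compound 3 in more than one place and offers no clean comparison.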